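The compounds below may be only part of what the source reports. "The series", "measured", "known", "first", "only" and "open" are said of these compounds alone.

Compound 1, `COc1ccccc1C(=O)Nc1cccc(NC(=O)c2ccc(Cl)cc2)c1`: in an in vitro functional assay on HEK293-A cells for antagonist activity at metabotropic glutamate receptor 5 (Rattus norvegicus), read by calcium flux (a lower number here means a stronger inhibitor, a higher number a weaker inhibitor), compound 1 gives > 30000 nM, which is a limit of the assay.
Compound 2, `COc1ccccc1C(=O)Nc1cccc(NC(=O)c2ccc(Cl)c(Cl)c2)c1`: in this assay compound 2 gives > 30000 nM, again a limit.
Compound 3, `COc1ccccc1C(=O)Nc1cccc(NC(=O)C(C)C)c1`: in this assay compound 3 gives > 30000 nM, also a limit.

Compound 1 therefore stands at the limit of > 30000 nM in this assay, at which 3 of the 3 values shown sit, and nothing places it above or below its two companions. The steps among the measured compounds, a step that the two limits leave unreadable from compound 1 to compound 2, a step that the two limits leave unreadable from compound 1 to compound 3 and a step that the two limits leave unreadable from compound 2 to compound 3, remain unreadable because the limit of > 30000 nM in this assay, at which 3 of the 3 values shown sit, hides both ends of each. The change to compound 4, `O=C(Nc1cccc(NC(=O)c2cccc(Cl)c2)c1)c1ccc(Cl)cc1`, is 3-chlorophenyl in place of 2-methoxyphenyl on a carbonyl carbon. Among the compounds with values here, none of the measured steps alters that side of the shared core, so no measured step gives a readable size that bears on it. Compound 4 is expected to sit at or near the same limit, with the step from compound 1 to compound 4 estimated as a number no higher from compound 1 to compound 4 (the limit leaves the size open). For compound 4 the estimate in this assay is 30000 nM, in a range from 10000 nM to 100000 nM.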

Compound 4, half-maximal inhibitory concentration: > 30000 nM
Compound 4 gave a limit, no number; the forecaster's own chance of this, stated with the estimate: 85%; the middle value lies on the limit itself.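

Compound 4, like compound 1, gives only a limit in this assay, so no step between the two can be read: the limit of > 30000 nM in this assay, at which 4 of the 4 values shown sit.

The compounds shown leave open which change to the shared core, if any, would bring a value inside that limit.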